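The compounds below may be only part of what the source reports. "The series", "measured", "known", "first", "only" and "open" are said of these compounds alone.

Of the compounds shown here, three measured so far share one core and differ only in the side chain attached to it. Compound 1 `CCCCCCC#Cc1cc2cn(COCCO)c(=O)nc2o1` carries a heptyl chain joined to the core through a triple bond. In a functional assay on HEL cells (Homo sapiens) (a higher number here means that more compound is tolerated, a lower number that less compound is tolerated), compound 1 reaches only a limit of the assay, > 50000 nM. Compound 2 `CCCCCCCc1cc2cn(COCCO)c(=O)nc2o1` carries a saturated chain of the same length, and in this assay compound 2 gives 140000 nM. Compound 3 `CCCCCCCCCC#Cc1cc2cn(COCCO)c(=O)nc2o1` keeps the triple bond and carries a longer chain. In this assay compound 3 likewise reaches only a limit of the assay, > 50000 nM. Going by the values given here, the single change measured within this set is a step that the two limits leave unreadable from compound 1 to compound 3. So compound 3 stands at the limit of > 50000 nM in this assay, at which 2 of the 3 values shown sit, with no number of its own to compare against compound 2.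

The next compound shortens the chain instead. Compound 4 `CCCCC#Cc1cc2cn(COCCO)c(=O)nc2o1` differs from compound 3 by hydrogen in place of pentyl on a saturated chain carbon, four bonds along the chain from a triple-bonded carbon. Among the compounds with values here, the one measured step that bears on chain length could not be read, and both compounds with a triple bond sit at the limit, so no step beyond the scatter is expected in this assay, and the estimated step that the limit leaves unreadable from compound 3 to compound 4 is taken as flat. Compound 4 is therefore expected to give about 100000 nM, somewhere between 40000 nM and 300000 nM, most likely again reported only as a limit.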

Compound 4, half-maximal cytotoxic concentration: > 50000 nM
Compound 4: no number, only a limit; the forecaster's own chance of this, stated with the estimate: 70%; the middle value does not contradict the limit.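

In this assay compound 4 gives > 50000 nM, which is a limit of the assay and not a number, so its steps from compound 1, compound 2 and compound 3 cannot be read. The compounds shown leave open whether chain length or the triple bond changes how much compound is tolerated at all.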